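The compounds below may be only part of what the source reports. "The series", "measured", "known", "first", "only" and "open" are said of these compounds alone.

Measured so far in a functional assay on OVCAR-5 cells (Homo sapiens) for inhibition, read by sulforhodamine B assay, with a stated time of 48 h; a lower number here means a stronger inhibitor of growth, a higher number a weaker inhibitor of growth:

- compound 1 (`O=C(Nc1cccc(-n2cc(-c3ccncc3)c(-c3ccc(Cl)c(O)c3)n2)c1)Nc1cccc(C(F)(F)F)c1`) gives > 32500 nM as a limit
- compound 2 (`COc1cc(-c2nn(-c3cccc(NC(=O)Nc4cc(C(F)(F)F)cc(C(F)(F)F)c4)c3)cc2-c2ccncc2)ccc1Cl`) gives 2470 nM as a number
- compound 3 (`COc1cc(-c2nn(-c3cccc(NC(=O)Nc4ccc(Cl)c(Cl)c4)c3)cc2-c2ccncc2)ccc1Cl`) gives > 50000 nM as a limit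

Compound 1 therefore stands at > 32500 nM as a limit, not as a true number. Compound 4 (`O=C(Nc1cccc(-n2cc(-c3ccncc3)c(-c3ccc(Cl)c(O)c3)n2)c1)Nc1ccc(Cl)c(Cl)c1`) keeps the core of compound 1 and changes one group: 3,4-dichlorophenyl in place of 3-(trifluoromethyl)phenyl on an amide-type nitrogen with 3,4-dichlorophenyl in place of 3-(trifluoromethyl)phenyl on an amide-type nitrogen. Compound 3 carries that same 3,4-dichlorophenyl group and gives > 50000 nM as a limit too. No step beyond the usual scatter is therefore expected in this assay and the result may again be only a limit. The expected step is a step that the limit leaves unreadable from compound 1 to compound 4 in this estimate. For compound 4 the estimated value is 35000 nM within a range of 12000 nM to 80000 nM as expected bounds.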

Compound 4, concentration for total growth inhibition: > 32500 nM
Compound 4 was reported as a limit; the forecaster's own chance of this, stated with the estimate: 70%; the middle value lies beyond the limit too.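

In this assay, within the data shown here, compound 4 gives > 32500 nM, which is a limit, and compound 1 and compound 3 also stand as limits, so no step between them can be read. As far as these compounds go, whether 3,4-dichlorophenyl or 3-(trifluoromethyl)phenyl gives the stronger inhibitor of growth stays open.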